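Methyl for chloro on a pyridinylamino dipeptidyl peptidase 9 series

A few compounds are considered here, and "the series" means these few. Any claim that something is new, unique, unknown or untested is made for them only; others in the source may bear on it.

Compounds measured so far:
compound 1, `Cc1ccnc(Nc2cc(N3CCNCC3)nc3ccnn23)c1`, > 100000 nM
compound 2, `N[C@@H]1CCCN(c2cc(Nc3cc(Cl)ccn3)n3nccc3n2)C1`, > 50000 nM
compound 3, `O=[N+]([O-])c1ccccc1Nc1cc(N2CCNCC2)nc2ccnn12`, > 100000 nM

In an assay on isolated protein for inhibition of Dipeptidyl peptidase 9 (Homo sapiens) (on this read-out higher numbers stand for weaker inhibition and lower numbers for stronger inhibition), compound 2 gives only a limit, > 50000 nM, and no number. The other two values shown are limits as well, at the limit of > 100000 nM in this assay, at which 2 of the 3 values shown sit, so compound 2 cannot be placed in order against them. Compound 4, `Cc1ccnc(Nc2cc(N3CCC[C@@H](N)C3)nc3ccnn23)c1`, has not yet been tested in this assay. It differs from compound 2 by methyl in place of chloro on an aromatic carbon. Compound 1 already carries a methyl at that position and sits at the limit of > 100000 nM in this assay, at which 2 of the 3 values shown sit, so no step beyond the scatter is expected from compound 2 to compound 4; the step that the limit leaves unreadable from compound 2 to compound 4 is estimated as flat, most likely ending again at a limit. Compound 4 is expected near 100000 nM, between 40000 nM and 300000 nM.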

Compound 4, half-maximal inhibitory concentration: > 100000 nM
Compound 4: a limit, no number; the forecaster's own chance of this, stated with the estimate: 90%; the middle value lies on the limit itself.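

Among these compounds, compound 1, compound 2 and compound 4 all give only limits in this assay, so no step among them can be read. The compounds shown leave open what actual value any of them has in this assay.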